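Inactive at the Limit: Trimming the Pyridinylmethyl Arm

A few compounds are considered here, and "the series" means these few. Any claim that something is new, unique, unknown or untested is made for them only; others in the source may bear on it.

Compound 1 `CN(C[C@H]1Cc2c(cccc2N2CCNC(C)(C)C2)CN1)[C@H]1CCCc2cccnc21`. In a functional assay on CCRF-CEM cells for agonist activity at C-X-C chemokine receptor type 4 (Homo sapiens), read by calcium flux, with a stated time of 25 min (a lower number here means that less compound is needed, a higher number that more compound is needed for the effect), compound 1 gives > 30000 nM, which is a limit of the assay.
Compound 2 `CC(C)N1CCN(c2cccc3c2C[C@H](CN(C)[C@H]2CCCc4cccnc42)NC3)CC1`. In this assay compound 2 gives > 30000 nM, again a limit.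
Compound 3 `CN(C[C@H]1Cc2c(cccc2N2CCN(Cc3ccccn3)CC2)CN1)[C@H]1CCCc2cccnc21`. In this assay compound 3 gives > 30000 nM, also a limit.

All three measured compounds sit at the limit described by the limit of > 30000 nM in this assay, at which 3 of the 3 values shown sit, so compound 3 stands nowhere distinguishable from compound 1 or compound 2. The two measured steps are accordingly unreadable: a step that the two limits leave unreadable from compound 1 to compound 2 and a step that the two limits leave unreadable from compound 2 to compound 3. Neither can tell whether the ring substituent on the shared core matters.

Compound 4 `CN1CCN(c2cccc3c2C[C@H](CN(C)[C@H]2CCCc4cccnc42)NC3)CC1` differs from compound 3 by hydrogen in place of pyridin-2-yl on a saturated chain carbon bound to an amine nitrogen in a ring. Going by the values given here, no measured step bears on this change in a readable way; the only information is that every variation of the group on the piperazine nitrogen so far leaves the compounds at the limit. Compound 4 is therefore expected to remain at or near that limit, with the step of a number no higher from compound 3 to compound 4 (the limit leaves the size open) estimated as essentially none beyond the scatter. Compound 4 is estimated at 30000 nM, within 8000 nM to 100000 nM.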

Compound 4, half-maximal effective concentration: > 30000 nM
Compound 4: no number, only a limit; the forecaster's own chance of this, stated with the estimate: 85%; the middle value sits exactly at the limit.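

No new step can be read from compound 4 to compound 1, compound 2 or compound 3, as each pair ends in limits: the limit of > 30000 nM in this assay, at which 4 of the 4 values shown sit.

The compounds shown leave open whether any of these group changes on the shared core alters the concentration needed in this assay.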